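Replacing Hydroxy with 2-Aminophenyl in Compound 3

The source may hold more compounds than are shown below. What is called first, only, known or untested is meant among the compounds shown, and "the series" means these compounds.

Measured in a functional assay on HeLa cells (Homo sapiens) for inhibition, read by MTT assay, with a stated time of 48 h; a higher number here means a weaker inhibitor, a lower number a stronger inhibitor:
Compound 1 `COc1ccc(/C=C/C(=O)NO)cc1OCC(=O)Nc1ccc(Cl)c(Cl)c1`: 13400 nM
Compound 2 `COc1ccc(NC(=O)COc2cc(/C=C/C(=O)NO)ccc2OC)cc1`: 4870 nM
Compound 3 `COc1ccc(/C=C/C(=O)NO)cc1OCC(=O)Nc1ccccc1F`: 3910 nM

Compound 3, at 3910 nM, has the lowest of the three numbers, but its lead is real only over compound 1, with a 3.4-fold lower number from compound 1 to compound 3 (0.53 log units; beyond the scatter). Compound 3 cannot be separated from compound 2, with a 1.2-fold lower number from compound 2 to compound 3 (0.10 log units; within the scatter). The third measured step, a 2.8-fold lower number from compound 1 to compound 2 (0.44 log units; beyond the scatter), is also modest.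

Compound 4 `COc1ccc(/C=C/C(=O)Nc2ccccc2N)cc1OCC(=O)Nc1ccccc1F` keeps the rest of compound 3 but carries 2-aminophenyl in place of hydroxy on an amide-type nitrogen. Among the measured compounds shown here, none of the measured steps makes this change. All three only exchange one phenyl group for another on an amide-type nitrogen, so they show how far the numbers have moved in this small set, not what replacing hydroxy will do. Even the largest of them, a 3.4-fold lower number from compound 1 to compound 3 (0.53 log units; beyond the scatter), is only a rough guide to size.

With no direct evidence, no step beyond the scatter is firmly expected in this assay, and the expected change is an estimated 1.5-fold higher number from compound 3 to compound 4 (0.19 log units; within the scatter). The uncertainty is wide and extends in both directions. For compound 4 the estimated value is 6000 nM, with an expected range from 1800 nM to 20000 nM.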

Compound 4, half-maximal inhibitory concentration: 20500 nM
Beside the measured number, compound 4's estimate is 3.4-fold (0.53 log units) below it; measured number above the stated range.
By their numbers in this assay, from the lowest: compounds 3 and 2 (each within the scatter of the next); then compounds 1 and 4 (each within the scatter of the next).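

In this assay, the change gives a 5.2-fold higher number from compound 3 to compound 4 (0.72 log units; beyond the scatter) and is the first step shown at the hydroxycarbamoyl end of the molecule, as the earlier steps only exchanged one phenyl group for another on the other amide-type nitrogen. This position therefore responds to substitution in this assay: the step lies beyond the scatter, although one heavy atom gives way to seven and a six-membered aromatic ring enters, while the hydrogen-bond donor and acceptor counts and the absence of net charge stay the same. Nothing available on this series explains the shift in the number, so the result stands as an observation only.

The compounds shown leave open which part of the change carries the step: the loss of hydroxy, the arrival of the ring, or the amino group on that ring, a question that a plain phenyl or a methyl on the same nitrogen would address. They also leave open whether 2-aminophenyl would give a step of similar size on the 4-methoxyphenyl or 3,4-dichlorophenyl amides.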